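A few compounds are considered here, and "the series" means these few. Any claim that something is new, unique, unknown or untested is made for them only; others in the source may bear on it.

Working notes on the series, read in a physicochemical assay for solubility; a lower number here means a less soluble compound, a higher number a more soluble compound. Compound 1 (`O=C(CN1CCCC1)N1CCC(NS(=O)(=O)c2cc(S(=O)(=O)c3ccccc3)ccc2C(F)(F)F)CC1`) gives 25000 nM, compound 2 (`O=C(CN1CCNCC1)N1CCC(NS(=O)(=O)c2cc(S(=O)(=O)c3ccccc3)ccc2C(F)(F)F)CC1`) gives 50000 nM and compound 3 (`CCNC(=O)N1CCC[C@H]1C(=O)N1CCC(NS(=O)(=O)c2cc(S(=O)(=O)c3ccccc3)ccc2C(F)(F)F)CC1`) gives 100000 nM. Compound 3 stands clear of one compound, a 4.0-fold higher number from compound 1 to compound 3 (0.60 log units; beyond the scatter), but not of the other, a 2.0-fold higher number from compound 2 to compound 3 (0.30 log units; within the scatter). The remaining step, a 2.0-fold higher number from compound 1 to compound 2 (0.30 log units; within the scatter), also stays within the scatter. Compound 4 (`CN(C)C(=O)N1CCC[C@H]1C(=O)N1CCC(NS(=O)(=O)c2cc(S(=O)(=O)c3ccccc3)ccc2C(F)(F)F)CC1`) follows from compound 3 with dimethylamino in place of ethylamino on a carbonyl carbon. Among the compounds with values here, no measured step makes this exchange. The three steps replace whole groups, and the largest is modest. No step beyond the scatter is therefore expected in this assay. The expected change is no change at the digits printed from compound 3 to compound 4 (within the scatter). For compound 4 the estimated value is 100000 nM, with an expected range of 50000 nM to 200000 nM.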

Compound 4, solubility: 100000 nM
For compound 4 middle estimate and measured number coincide at the digits printed; measured number inside the range.
By their numbers in this assay, from the lowest: compounds 1, 2, 3 and 4 (each within the scatter of the next, the first and the last beyond it).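

In this assay, within the data shown here, the first exchange confined to this carbonyl carbon, dimethylamino in place of ethylamino, removes the hydrogen-bond donor of ethylamino and leaves the read-out in place (no change at the digits printed from compound 3 to compound 4 (within the scatter)). Compound 4 also stands as compound 3 does against the other two compounds (a 2.0-fold higher number from compound 2 to compound 4 (0.30 log units; within the scatter); a 4.0-fold higher number from compound 1 to compound 4 (0.60 log units; beyond the scatter)). No supporting measurement is available to explain these steps.

From the compounds shown here alone, whether diethylamino or morpholin-4-yl on this carbonyl carbon would hold the read-out at this level stays open.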